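From carbamoyl to methoxycarbonyl on the shared core

The source may hold more compounds than are shown below. What is called first, only, known or untested is meant among the compounds shown, and "the series" means these compounds.

Compound 1 `CCO[C@H]1C[C@@H](c2coc3ccc(Br)cc3c2=O)N(c2ccccc2)O1`: 21500 nM
Compound 2 `Cc1ccc2occ([C@@H]3[C@H]4C(=O)N(c5ccccc5)C(=O)[C@H]4ON3c3ccccc3)c(=O)c2c1`: > 60000 nM
Compound 3 `NC(=O)[C@H]1C[C@@H](c2coc3ccccc3c2=O)N(c2ccccc2)O1`: > 60000 nM

All three values come from a functional assay on A549 cells (Homo sapiens) for inhibition, read by sulforhodamine B assay, with a stated time of 48 h; a higher number here means a weaker inhibitor, a lower number a stronger inhibitor. Compound 3 stands only at a limit of the assay, its value > 60000 nM being a bound and not a number. It shares this position with the limit of > 60000 nM in this assay, at which 2 of the 3 values shown sit. Compound 4 `COC(=O)[C@H]1C[C@@H](c2coc3ccccc3c2=O)N(c2ccccc2)O1` differs from compound 3 in one place: methoxy in place of amino on a carbonyl carbon. No step between two measured compounds is shown, so nothing measured tells how large a step this change gives in this assay. Compound 4 is expected to remain weak, with a step of an at least 1.2-fold lower number from compound 3 to compound 4 (0.07 log units; that floor lies within the scatter) that is small and not clearly beyond the scatter. Compound 4 is estimated at 50000 nM, in the range 15000 nM to 150000 nM, with a fair chance that only a limit is reported.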

Compound 4, half-maximal inhibitory concentration: > 60000 nM
Compound 4: a limit, no number; the forecaster's own chance of this, stated with the estimate: 55%; at least 1.2-fold (0.07 log units) between middle value and limit.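

Compound 3 and compound 4 both stand only at a limit in this assay, so no step between them can be read: the limit of > 60000 nM in this assay, at which 3 of the 4 values shown sit.

The compounds shown leave open whether methoxy in place of amino on a carbonyl carbon changes inhibition at all.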